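Notes on the step from cyano to tetrazole

A few compounds are considered here, and "the series" means these few. Any claim that something is new, unique, unknown or untested is made for them only; others in the source may bear on it.

Measured in a functional assay on LNCaP cells (Homo sapiens) for cytotoxicity, read by MTT assay, with a stated time of 5 days; on this read-out higher numbers stand for weaker inhibition of growth and lower numbers for stronger inhibition of growth:
- compound 1 `Cc1ccc(S(=O)(=O)Nc2ccc(C)cc2[N+](=O)[O-])cc1`: 39800 nM
- compound 2 `Cc1ccc(C#N)c(NS(=O)(=O)c2ccc(F)cc2)c1`: 30200 nM

In this assay compound 2 gives 30200 nM, which lies within the scatter of compound 1 at 39800 nM. The two values do not separate. Compound 3 `Cc1ccc(-c2nnn[nH]2)c(NS(=O)(=O)c2ccc(F)cc2)c1` carries 1H-tetrazol-5-yl in place of cyano on an aromatic carbon, ortho to a large group and para to a methyl group: 1H-tetrazol-5-yl in place of cyano on an aromatic carbon. Among the compounds with values here, no measured step covers this change, so nothing beyond the scatter is expected. The expected step is a 1.0-fold lower number from compound 2 to compound 3 (0.00 log units; within the scatter). Compound 3 is estimated at 30000 nM, with an expected range of 10000 nM to 90000 nM.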

Compound 3, concentration for 50% growth inhibition: > 100000 nM
Compound 3: a limit, no number; the forecaster's own chance of this, stated with the estimate: 25%; middle value at least 3.3-fold (0.52 log units) away from the limit.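

In this assay, 1H-tetrazol-5-yl in place of cyano on this aromatic carbon gives an at least 3.3-fold higher number from compound 2 to compound 3 (0.51 log units; beyond the scatter), so growth inhibition at this position weakens with this change, which compound 1 and compound 2 alone could not show. The result for compound 3 is a limit and not a number, so the step has a lower bound only: the limit of > 100000 nM in this assay, at which 1 of the 3 values shown sits.

As far as these compounds go, whether a carboxylic acid or an amine at the same position would stay close to compound 2 remains open. Also open, from the compounds shown here alone, is whether a smaller step would appear with an amide there.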